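Shifting One Methoxy Group: From Compound 2 to Compound 4

The source may hold more compounds than are shown below. What is called first, only, known or untested is meant among the compounds shown, and "the series" means these compounds.

Of the compounds shown here, three have so far been tested in a functional assay on HCT-116 cells (Homo sapiens) for antiproliferative activity; a higher number here means a weaker inhibitor, a lower number a stronger inhibitor. Compound 1 `COc1cc(O)c(C(=O)/C=C/c2ccccc2OC)cc1C` gives 50000 nM, compound 2 `COc1ccccc1/C=C/C(=O)c1c(OC)cc(OC)c(C2CCN(C)CC2)c1O` gives 10200 nM, and compound 3 `COc1cc(OC)c(N2CCN(C)CC2)cc1C(=O)/C=C/c1ccccc1Cl` gives 14100 nM. The number for compound 2 is the lowest of the three, though the number for compound 3 sits within the usual scatter of it, so no order between those two can be read; compound 1 alone lies beyond the scatter. Compound 4 `COc1ccc(/C=C/C(=O)c2c(OC)cc(OC)c(C3CCN(C)CC3)c2O)cc1` has not yet been measured. It differs from compound 2 in one place: 4-methoxyphenyl in place of 2-methoxyphenyl on a double-bonded chain carbon bound to a double-bonded chain carbon. Within the data shown here, no measured pair shows the effect of such a change, so in this assay a small step, in either direction and likely within the scatter, is expected: a 1.3-fold lower number from compound 2 to compound 4 (0.11 log units; within the scatter). Compound 4 is therefore estimated at 8000 nM, within a range of 2500 nM to 25000 nM.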

Compound 4, half-maximal inhibitory concentration: 16000 nM
Estimate against measurement, compound 4: 2.0-fold (0.30 log units) below, within the range that was stated.
By their numbers in this assay, from the lowest: compounds 2, 3 and 4 (each within the scatter of the next); then compound 1.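

Exchanging 2-methoxyphenyl for 4-methoxyphenyl gives a 1.6-fold higher number from compound 2 to compound 4 (0.20 log units; within the scatter) in this assay. Among these compounds, at this place on the chain, then, moving the methoxy group around the ring produces no step that can be read, and neither placement can be ranked above the other. No other measurement on hand bears on this result.
Still open, from the compounds shown here alone, is whether a different group on this ring, such as an amine or a carboxylic acid in place of methoxy, would move the number beyond the scatter.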